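The source may report more compounds than this note shows. Statements on the series, on what has been measured and on what is new or still open speak of the compounds shown alone.

For the measured compounds named here, in an ADME assay on cells (Hepatocyte, Homo sapiens) for metabolic stability, with a stated time of 30 min (a lower number here means that less of the compound is left, a higher number that more of the compound is left), compound 2 (`O=C(OC1CCC(CN2CCN(c3cc(=O)c4cc(C(F)(F)F)cc([N+](=O)[O-])c4s3)CC2)CC1)c1ccc(F)cc1`) gives 3%, and the only other measured compound, compound 1 (`Cc1ccc(C(=O)OC2CCC(CN3CCN(c4cc(=O)c5cc(C(F)(F)F)cc([N+](=O)[O-])c5s4)CC3)CC2)cc1`), gives 9.7%. The two cannot be told apart. Going by the values given here, the one measured step, a number 6.7 percentage points lower from compound 1 to compound 2 (within the scatter), is fluoro in place of methyl on an aromatic carbon, and it stays within the scatter. Compound 3 (`O=c1cc(N2CCN(CC3CCC(O)CC3)CC2)sc2c([N+](=O)[O-])cc(C(F)(F)F)cc12`) differs from compound 2 by hydrogen in place of (4-fluorophenyl)carbonyl on an oxygen on a saturated carbon. Among the compounds with values here, the measured step only swaps a substituent on the aromatic ring, whereas here the whole group leaves, and no measured pair shows such a removal. Compound 2, at 3%, leaves little room downward, so a rise beyond the scatter is expected, though with wide uncertainty. The expected change is a number 22 percentage points higher from compound 2 to compound 3 (beyond the scatter). For compound 3 the estimated value is 25%, with an expected range of 6% to 60%.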

Compound 3, percent of the compound remaining: 72.7%
Compound 3: the middle estimate sits 47.7 percentage points below what was measured, and the stated range ends below it.
By their numbers in this assay, from the lowest: compounds 2 and 1 (each within the scatter of the next); then compound 3.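

In this assay, hydrogen in place of (4-fluorophenyl)carbonyl on the oxygen gives a large step (a number 69.7 percentage points higher from compound 2 to compound 3 (beyond the scatter)), and hydrogen in place of (4-methylphenyl)carbonyl on the same oxygen gives a large step as well (a number 63 percentage points higher from compound 1 to compound 3 (beyond the scatter)). The oxygen on the saturated carbon is thus a place where a change moves this read-out far beyond the scatter, whereas the swap on the aromatic ring stayed within it (a number 6.7 percentage points lower from compound 1 to compound 2 (within the scatter)). Nothing available accounts for the size of these steps.

The compounds shown carry on this oxygen only hydrogen or an aromatic carbonyl group, so it remains open whether a small group such as acetyl or methyl would give a number near that of compound 3. As far as these compounds go, it also remains open whether an amine in place of the hydroxy would do the same.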